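Swapping a basic side chain for a carboxylic group

The source may hold more compounds than are shown below. What is called first, only, known or untested is meant among the compounds shown, and "the series" means these compounds.

Compound 1 `CCN(CC)CCNC(=O)c1ccc(C(CC)(CC)c2ccc(OCS(=O)(=O)c3ccccc3)c(C)c2)n1CC` carries a 2-(diethylamino)ethyl group on its amide-type nitrogen. In a functional assay on BXPC-3 cells (Homo sapiens) for antiproliferative activity, read by MTT assay, with a stated time of 24 h (on this read-out lower numbers stand for stronger inhibition and higher numbers for weaker inhibition), compound 1 gives 6270 nM, the lowest number among the three measured compounds. Compound 2 `CCn1c(C(=O)NC2(CO)CC2)ccc1C(CC)(CC)c1ccc(OCS(=O)(=O)c2ccccc2)c(C)c1` gives 45400 nM, and compound 3 `CCn1c(C(=O)NCCCO)ccc1C(CC)(CC)c1ccc(OCS(=O)(=O)c2ccccc2)c(C)c1` gives 26600 nM. Both of these put a hydroxyl-bearing group in place of the diethylamino-bearing chain: the step of a 7.2-fold higher number from compound 1 to compound 2 (0.86 log units; beyond the scatter) and the step of a 4.2-fold higher number from compound 1 to compound 3 (0.63 log units; beyond the scatter) each weakened inhibition, while the comparison a 1.7-fold lower number from compound 2 to compound 3 (0.23 log units; within the scatter) shows the two hydroxyl variants sitting close to one another.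

Compound 4 `CCn1c(C(=O)N[C@@H](C)C(=O)O)ccc1C(CC)(CC)c1ccc(OCS(=O)(=O)c2ccccc2)c(C)c1` is the next variant. Relative to compound 1 the change is 1-carboxyethyl in place of 2-(diethylamino)ethyl on an amide-type nitrogen. As in the two measured steps, the diethylamino group is removed and a group carrying one hydrogen-bond donor takes its place, here the 1-carboxyethyl group. The two steps from compound 1 that bear on this were both modest and both went toward higher numbers, so a step of similar size in the same direction is expected for compound 4 in this assay. The expected step from compound 1 to compound 4 is a 4.8-fold higher number from compound 1 to compound 4 (0.68 log units; beyond the scatter). Compound 4 is therefore estimated at 30000 nM, with a range from 10000 nM to 100000 nM.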

Compound 4, half-maximal inhibitory concentration: 20800 nM
Compound 4: middle estimate off by 1.4-fold (0.16 log units), on the high side; the measured number falls inside the stated range.
By their numbers in this assay, from the lowest: compound 1; then compounds 4, 3 and 2 (each within the scatter of the next, the first and the last beyond it).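

In this assay, the 1-carboxyethyl group on the amide-type nitrogen also falls short of the 2-(diethylamino)ethyl group (a 3.3-fold higher number from compound 1 to compound 4 (0.52 log units; beyond the scatter)), so all three replacements now shown give higher numbers than compound 1. Among these replacements, 1-carboxyethyl and 3-hydroxypropyl cannot be told apart (a 1.3-fold lower number from compound 3 to compound 4 (0.11 log units; within the scatter)), whereas the gap to 1-(hydroxymethyl)cyclopropyl is modest but real (a 2.2-fold lower number from compound 2 to compound 4 (0.34 log units; beyond the scatter)), making this the first comparison among the replacements to lie beyond the scatter. Nothing measured here accounts for these differences, so the data show the size of each change but not what lies behind it.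

The compounds shown leave open which part of the 2-(diethylamino)ethyl group matters, since a 2-(dimethylamino)ethyl group or a longer 3-(diethylamino)propyl chain could show whether the number of compound 1 depends on the ethyl groups or on the length of the chain. As far as these compounds go, for the 1-carboxyethyl group, the methyl ester and the mirror-image form at its defined stereocentre also remain open, and either would show whether the carboxylic acid or its spatial arrangement has any bearing on the number.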